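This account rests on a few compounds, and the source may have more. Where it says the series, first, only, none or still open, it means among the compounds named here.

Working notes on the series. In an assay on cells for inhibition of histone-lysine N-methyltransferase EZH2 (Homo sapiens), read by ELISA, with a stated time of 72 h (on this read-out higher numbers stand for weaker inhibition and lower numbers for stronger inhibition), compound 1 `Cc1cc(C)c(CN2CCc3c(Cl)cc([C@@H](CO)[C@@H]4CCCO4)c(Cl)c3C2=O)c(=O)[nH]1` gives 1570 nM. Compound 3 `Cc1cc(C)c(CN2CCc3c(Cl)cc([C@@H](CO)[C@H]4CCCO4)c(Cl)c3C2=O)c(=O)[nH]1` gives 1020 nM in this assay; the two compounds have the same atoms and bonds, and the fact that compounds 1 and 3 differ only in the configuration as drawn means the step of a 1.5-fold lower number from compound 1 to compound 3 (0.19 log units; within the scatter) is a pure change of configuration as drawn, and it lies within the scatter. Compound 3 therefore holds the lowest of the two single numbers, with compound 1 nearest and within the scatter of it, so no order between them is claimed. Compound 2 `COC(c1cc(Cl)c2c(c1Cl)C(=O)N(Cc1c(C)cc(C)[nH]c1=O)CC2)C1CCOCC1` gives 1460 nM; 9 nM (2 entries) in this assay; the several entries of compound 2 in this assay, 1460 nM; 9 nM (2 entries) shows repeated entries far apart, so compound 2 offers no firm anchor.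

Compound 4 `Cc1cc(C)c(CN2CCc3c(Cl)cc([C@H](C)CO)c(Cl)c3C2=O)c(=O)[nH]1` is reached from compound 3 by the change (methyl in place of oxolan-2-yl on a saturated chain carbon bound to an aromatic carbon and a saturated chain carbon). Within the data shown here, no measured step in this assay concerns a change of this kind: the only measured step, a 1.5-fold lower number from compound 1 to compound 3 (0.19 log units; within the scatter), alters configuration alone and is within the scatter, so it sets neither direction nor size for the loss of the ring. With a group of five heavy atoms and one acceptor replaced by a single carbon, a modest weakening is expected, a 2.5-fold higher number from compound 3 to compound 4 (0.39 log units; beyond the scatter), though a result within the scatter would not surprise. The estimate for compound 4 in this assay is 2500 nM, expected to fall between 800 nM and 8000 nM.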

Compound 4, half-maximal inhibitory concentration: 129 nM
Beside the measured number, compound 4's estimate is 19-fold (1.29 log units) above it; measured number below the stated range.
By their numbers in this assay, from the lowest: compound 4; then compounds 3 and 1 (each within the scatter of the next).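

In this assay, methyl in place of oxolan-2-yl on a saturated chain carbon bound to an aromatic carbon and a saturated chain carbon gives a 7.9-fold lower number from compound 3 to compound 4 (0.90 log units; beyond the scatter), and the same change gives a 12-fold lower number from compound 1 to compound 4 (1.09 log units; beyond the scatter). The oxolan-2-yl ring is therefore not required for inhibition at this position: both compounds that carry it have higher numbers than the methyl compound, whereas the change of configuration alone, a 1.5-fold lower number from compound 1 to compound 3 (0.19 log units; within the scatter), stays within the scatter, so here the change of group is the step that can be read and the change of configuration is not. Nothing measured in the series accounts for why removing the ring lowers the number.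

Whether the trend continues with other groups on this carbon remains open, since the compounds shown give no reading for ethyl, a longer chain, an amine or a carboxylic acid there. Also open, from the compounds shown here alone, is how far the number depends on the configuration at this carbon once methyl is in place, and whether the hydroxymethyl group on the same chain contributes to the result.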